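Methoxy on the chlorophenyl ring: a small step from compound 1

The compounds below may be only part of what the source reports. "The series", "measured", "known", "first", "only" and "open" are said of these compounds alone.

Compound 1, `Cc1oc(-c2ccccc2Cl)nc1CN1CCC(C(=O)NCCCN2C[C@H](C)C[C@H](C)C2)CC1`, 352 10^-6 cm/s
Compound 2, `Cc1ccccc1-c1nc(CN2CCC(C(=O)NCCCN3CCCC(C(C)C)C3)CC2)c(C)o1`, "not determined" (no result reported)
Compound 3, `Cc1ccccc1-c1nc(CN2CCC(C(=O)N3CCN(C4CCN(C)CC4)CC3)CC2)c(C)o1`, < 3.2 10^-6 cm/s

Three compounds share a common core and were followed in a physicochemical assay for permeability, using PAMPA; a higher number here means that the compound crosses the layer faster, a lower number that the compound crosses the layer more slowly. Within the data shown here, compound 1 gives 352 10^-6 cm/s, the only full number among the three. For compound 2 the result in this assay is "not determined" (no result reported). Compound 3 reaches only a limit of the assay in this assay, reported as < 3.2 10^-6 cm/s; it is a limit, not a number, and the limit of < 3.2 10^-6 cm/s in this assay, at which 1 of the 3 values shown sits, marks where it sits. Among the measured compounds shown here, compound 1 therefore stands alone with a measured value, and no step between two measured compounds can be drawn from these data.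

Compound 4, `COc1cccc(Cl)c1-c1nc(CN2CCC(C(=O)NCCCN3C[C@H](C)C[C@H](C)C3)CC2)c(C)o1`, is not yet measured. It differs from compound 1 in one place: methoxy in place of hydrogen on an aromatic carbon. The change is small, and nothing measured here speaks to the effect of a methoxy group on passage through the layer. The step of a 1.2-fold lower number from compound 1 to compound 4 (0.07 log units; within the scatter) is expected to stay within the scatter of repeated measurements, with no clear direction. For compound 4 a value of 300 10^-6 cm/s is estimated, within a range from 150 10^-6 cm/s to 600 10^-6 cm/s.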

Compound 4, apparent permeability: 51 10^-6 cm/s
Beside the measured number, compound 4's estimate is 5.9-fold (0.77 log units) above it, outside the stated range (below it).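

In this assay, the aromatic carbon that carries methoxy, ortho to a large group and meta to a chloro group, proves not to be a silent place on the ring: putting methoxy in place of hydrogen there gives a 6.9-fold lower number from compound 1 to compound 4 (0.84 log units; beyond the scatter) in the read-out. The earlier compounds offered no step at all, so this is the first measured pair shown that differs in one place, and it shows that an addition of only 2 heavy atoms, with no ring and no net charge, can be enough to move the number clearly. Nothing measured among these compounds gives a cause for this step.

On these data alone, whether a fluoro, a methyl or a hydroxyl group on this same carbon would give a step of like size stays open, as does whether an ethoxy group would give a larger one. Also open, as far as these compounds go, is whether methoxy on another carbon of the ring would act in the same way, and whether the same change would carry over to a shared core bearing a different amine at the end of its chain.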